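The source may report more compounds than this note shows. Statements on the series, on what has been measured and on what is new or still open speak of the compounds shown alone.

Compound 3 `Cc1cc(C)c(NC(=O)N(Cc2cccc(-n3cccc3)c2)C2CCCCCC2)c(C)c1` gives the lowest of the three numbers measured in an assay on microsomes from intestine for inhibition of acyl-CoA:cholesterol acyltransferase (Oryctolagus cuniculus); on this read-out lower numbers stand for stronger inhibition and higher numbers for weaker inhibition. In this assay compound 3 gives 20 nM, while compound 2 `Cc1cc(C)c(NC(=O)N(Cc2cccc(-c3cc[nH]n3)c2)C2CCCC2)c(C)c1` gives 22 nM, the two lying within the scatter of each other, and compound 1 `Cc1cc(C)c(NC(=O)N(Cc2cccc(-c3csc(C)n3)c2)C2CCCCCC2)c(C)c1` gives 180 nM. For the measured compounds named here, the one single-point step among the measured compounds, a 9.0-fold lower number from compound 1 to compound 3 (0.95 log units; beyond the scatter), is the only change beyond the scatter seen here.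

Compound 4 `Cc1cc(C)c(NC(=O)N(Cc2cccc(-c3cc[nH]n3)c2)C2CCCCCC2)c(C)c1` differs from compound 3 in one place: 1H-pyrazol-3-yl in place of 1H-pyrrol-1-yl on an aromatic carbon. Going by the values given here, no measured step exchanges exactly these two groups. The nearest guide is compound 2, which carries the same 1H-pyrazol-3-yl group as compound 4 and, in this assay, gives a number within the scatter of that of compound 3. On that basis no step beyond the scatter is expected for compound 4, with the estimated step being a 1.3-fold higher number from compound 3 to compound 4 (0.10 log units; within the scatter). Compound 4 is therefore expected to give about 25 nM in this assay, within a range from 10 nM to 60 nM.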

Compound 4, half-maximal inhibitory concentration: 65 nM
Compound 4: middle estimate off by 2.6-fold (0.41 log units), on the low side; the whole stated range lies below it.
By their numbers in this assay, from the lowest: compounds 3 and 2 (each within the scatter of the next); then compound 4; then compound 1.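

With cycloheptyl held on the amide-type nitrogen, the position on the aromatic carbon, meta to a large group, does not treat 1H-pyrazol-3-yl and 1H-pyrrol-1-yl alike: in this assay the exchange gives a 3.3-fold higher number from compound 3 to compound 4 (0.51 log units; beyond the scatter). The same position also separates 1H-pyrazol-3-yl from 2-methyl-1,3-thiazol-4-yl, with a 2.8-fold lower number from compound 1 to compound 4 (0.44 log units; beyond the scatter), so these three five-membered aromatic rings now fall into a clear order on one background. The group on the amide-type nitrogen also counts, as cycloheptyl in place of cyclopentyl gives a 3.0-fold higher number from compound 2 to compound 4 (0.47 log units; beyond the scatter) with 1H-pyrazol-3-yl held.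

No measurement here accounts for any of these differences. From the compounds shown here alone, it remains open whether cyclopentyl would give the same gain with 1H-pyrrol-1-yl, and how a cyclohexyl ring on that nitrogen or a carboxylic acid on the aromatic carbon would read.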